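Triazole series, aromatase inhibition: notes toward compound 4

The source may report more compounds than this note shows. Statements on the series, on what has been measured and on what is new or still open speak of the compounds shown alone.

Measured compounds:
compound 1 `N#Cc1ccc(C(c2ccc(C#N)cc2)n2cc(COc3ccc(Cl)cc3)nn2)cc1` — 16100 nM
compound 2 `N#Cc1ccc(C(c2ccc(C#N)cc2)n2cc(COc3ccc(-c4ccccc4)cc3)nn2)cc1` — 13400 nM
compound 3 `CCCCCCc1cn(C(c2ccccc2)c2ccccc2)nn1` — 14800 nM

In an assay on isolated protein for inhibition of Aromatase (Homo sapiens), read by fluorescence and colorimetric assay, with a stated time of 30 min (a higher number here means a weaker inhibitor, a lower number a stronger inhibitor), the three measured compounds give numbers that lie close together. Compound 3 sits among them: its value differs from that of compound 1 and from that of compound 2 by amounts the scatter covers, so no ranking of the three can be read from the numbers. Within the data shown here, the one measured step, a 1.2-fold lower number from compound 1 to compound 2 (0.08 log units; within the scatter), likewise does not move the number beyond the scatter.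

Compound 4 `Clc1ccc(OCc2cn(C(c3ccccc3)c3ccccc3)nn2)cc1` arises from compound 3 by the change (4-chlorophenoxy in place of pentyl on a saturated chain carbon bound to an aromatic carbon). Among the measured compounds shown here, no measured step covers this exchange directly; the step of a 1.2-fold lower number from compound 1 to compound 2 (0.08 log units; within the scatter) alters a substituent on the 4-chlorophenoxy ring rather than exchanging a chain for that group. What does bear on it is that compound 1, which also carries a 4-chlorophenoxy group on its core, and compound 3, which carries the hexyl chain on a different core, lie within the scatter of each other. Because compound 1 gives 16100 nM and compound 3 gives 14800 nM, two numbers that the scatter covers, the expected step is a 1.0-fold higher number from compound 3 to compound 4 (0.01 log units; within the scatter), none beyond the scatter. The estimate for compound 4 in this assay is 15000 nM, with a range from 7000 nM to 32000 nM.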

Compound 4, half-maximal inhibitory concentration: 13400 nM
Compound 4: the middle estimate sits 1.1-fold (0.05 log units) above what was measured; the measured number falls inside the stated range.
By their numbers in this assay, from the lowest: compounds 2, 4, 3 and 1 (each within the scatter of the next).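

Working note on the saturated chain carbon bound to an aromatic carbon: in this assay, exchanging pentyl for 4-chlorophenoxy gives a 1.1-fold lower number from compound 3 to compound 4 (0.04 log units; within the scatter), so this position accepts an added six-membered aromatic ring and an oxygen with no step beyond the scatter. The earlier measured step altered only the substituent on the aromatic ring of the phenoxy group, whereas this one replaces the whole hexyl chain with (4-chlorophenoxy)methyl and shows that even this larger exchange on the shared core gives no separation in the number. No supporting measurement is available to account for this result.

The compounds shown leave open whether any group at this position can move the number beyond the scatter, for example an amine, a carboxylic acid or a chain longer than hexyl. Also open is what a single nitrile on the core of compound 4 would do, as the only nitrile-bearing compounds shown also differ from compound 4 in more than one place.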